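The compounds below may be only part of what the source reports. "The series", "measured", "known", "first", "only" and "open" are said of these compounds alone.

Measured so far in a functional assay on MCF7 cells (Homo sapiens) for antiproliferative activity, read by MTT assay, with a stated time of 48 h; a lower number here means a stronger inhibitor, a higher number a weaker inhibitor:
- compound 1 `N=C(N)N/N=C(/C=C/c1ccc(Cl)cc1)c1ccccc1` gives 700 nM
- compound 2 `N=C(N)N/N=C(/C=C/c1ccc(Br)cc1)c1ccccc1` gives 250 nM

Not yet measured: compound 3 `N=C(N)N/N=C(/C=C/c1ccccc1)c1ccccc1`

Within the data shown here, of the two numbers in this assay, the lower belongs to compound 2 at 250 nM, with compound 1 as its only neighbour.

The next change is hydrogen in place of bromo on an aromatic carbon, which is hydrogen in place of bromo on an aromatic carbon, para to a large group. Among the measured compounds shown here, one measured step bears on it: a 2.8-fold lower number from compound 1 to compound 2 (0.45 log units; beyond the scatter), with bromo in place of chloro on an aromatic carbon. That step is modest but beyond the scatter. For the measured compounds named here, it compares two halogens only, and no compound without a halogen has a number yet, so the data do not directly show what removing the bromo does. Compound 1 does show that losing the bromo for chloro comes with a higher number, so the same direction is expected here, with wide uncertainty. The expected change is a 4.0-fold higher number from compound 2 to compound 3 (0.60 log units; beyond the scatter), a modest to moderate rise resting on that single step. For compound 3 the estimated value is 1000 nM, with an expected range from 300 nM to 3500 nM.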

Compound 3, half-maximal inhibitory concentration: 17000 nM
The estimate for compound 3 lay 17-fold (1.23 log units) below the measured number; measured number above the stated range.
By their numbers in this assay, from the lowest: compound 2; then compound 1; then compound 3.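

In this assay the substituent on this aromatic carbon, para to a large group, matters far more than the comparison of the two halogens suggested: hydrogen in place of bromo gives a 68-fold higher number from compound 2 to compound 3 (1.83 log units; beyond the scatter) and hydrogen in place of chloro gives a 24-fold higher number from compound 1 to compound 3 (1.39 log units; beyond the scatter) in the same series. Both steps are much larger than a 2.8-fold lower number from compound 1 to compound 2 (0.45 log units; beyond the scatter) so within these three compounds, the choice between chloro and bromo is a smaller matter than whether a halogen occupies the position at all. Nothing available explains why removing the halogen costs this much.

The compounds shown leave open whether the large rise in the number is specific to halogens, since a methyl or methoxy group at the same carbon would separate a halogen requirement from a need for any substituent there. They also leave open whether the order from chloro to bromo extends to fluoro or iodo, and whether a halogen on the other phenyl ring of the shared core would have any comparable effect.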